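Methoxy for chloro on a carbamate pyrazole series

The source may hold more compounds than are shown below. What is called first, only, known or untested is meant among the compounds shown, and "the series" means these compounds.

Measured compounds:
compound 1 `NC(=O)c1cc(-c2cccc(OC(=O)NC3CCCCC3)c2)n(-c2ccc(Cl)cc2)n1` gives 174 nM in an assay on isolated protein for inhibition of Fatty-acid amide hydrolase 1 (Homo sapiens), read by fluorescence, with a stated time of 30 min; a lower number here means a stronger inhibitor, a higher number a weaker inhibitor
compound 2 `COc1ccc(-n2nc(C(N)=O)cc2-c2cccc(OC(=O)NC3CCCCC3)c2)cc1` gives 743 nM in this assay
compound 3 `CCOC(=O)c1cc(-c2cccc(OC(=O)NC3CCCCC3)c2)nn1-c1ccc(Cl)cc1` gives 353 nM in this assay

Compound 1 and compound 2 differ in one place: methoxy in place of chloro on an aromatic carbon. That change brought a 4.3-fold higher number from compound 1 to compound 2 (0.63 log units; beyond the scatter). Compound 3 carries a different core; the difference between the core of compound 1 and the core of compound 3 is not broken down here, and the two values show compound 3 sitting beyond the scatter above compound 1 and below compound 2.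

Compound 4 `CCOC(=O)c1cc(-c2cccc(OC(=O)NC3CCCCC3)c2)nn1-c1ccc(OC)cc1` has not yet been measured. It stands to compound 3 as compound 2 stands to compound 1: methoxy in place of chloro on an aromatic carbon. The place is the same in both pairs, so this is the same change made a second time, on the core of compound 3.

The expectation for compound 4 rests on a single prior instance, the step from compound 1 to compound 2, which was a 4.3-fold higher number from compound 1 to compound 2 (0.63 log units; beyond the scatter). A step of similar size is expected here, a 4.0-fold higher number from compound 3 to compound 4 (0.60 log units; beyond the scatter), and compound 4 is expected to give about 1400 nM in this assay, with a plausible range from 500 nM to 4000 nM.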

Compound 4, half-maximal inhibitory concentration: 407 nM
Compound 4: the middle estimate sits 3.4-fold (0.54 log units) above what was measured; the measured number lies below the stated range.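

On the core of compound 3, methoxy in place of chloro brought a 1.2-fold higher number from compound 3 to compound 4 (0.06 log units; within the scatter) in this assay, so the two groups could not be told apart there. Set beside the same change on the core of compound 1, the step did not carry over at its earlier size: the same change on two cores in this assay, a 4.3-fold higher number (0.63 log units; beyond the scatter) from compound 1 to compound 2 and a 1.2-fold higher number (0.06 log units; within the scatter) from compound 3 to compound 4, 3.7-fold (0.57 log units) apart, beyond the scatter of two such steps This shows that, for these two pairs, the size of the step depends on the core it is made on, but it does not show which feature of the cores is responsible, and two pairs give no rule for any further core.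

The compounds shown leave open how either core would respond to other groups in place of chloro and methoxy, such as fluoro or a nitrile, and whether a carboxylic acid at the site of the ester would behave like either core. They also leave open whether the cyclohexyl group on the carbamate, exchanged for a longer chain, would alter the step.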